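Series notes: chloro in place of methyl, compound 2 to compound 3

The source may report more compounds than this note shows. Statements on the series, on what has been measured and on what is new or still open speak of the compounds shown alone.

Of the compounds shown here, two have been measured in a functional assay on the whole organism (strain Wistar) with Rattus norvegicus as the target, with a stated time of 15 days, at a dose of 3 mg/kg by the oral route; a lower number here means a weaker effect, a higher number a stronger effect of the compound at the dose given. Compound 1 `O=C1NC(=O)/C(=C/c2ccc(OCc3csc(-c4ccccc4)n3)cc2)S1` gives 25.2% in this assay. Compound 2 `Cc1ccc(-c2nnc(SCCOc3ccc(/C=C4\SC(=O)NC4=O)cc3)[nH]2)cc1` gives 25.2% in this assay; at the digits as reported it stands level with compound 1, and the two values lie within the usual scatter of each other, so no order between them can be read. Among the compounds with values here, no pair of measured compounds differs in only one place, so no measured step is available to calibrate any single change.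

Compound 3 `O=C1NC(=O)/C(=C/c2ccc(OCCSc3nnc(-c4ccc(Cl)cc4)[nH]3)cc2)S1` has not yet been measured in this assay. Its difference from compound 2 is chloro in place of methyl on an aromatic carbon. Within the data shown here, the swap exchanges 1 heavy atom for 1 heavy atom on an aromatic carbon of a six-membered aromatic ring of carbon only, para to a large group, and nothing among the measured compounds shows what such a swap does here. The expected step in this assay is therefore a number 0.8 percentage points higher from compound 2 to compound 3 (within the scatter), in no preferred direction and not beyond the scatter. Compound 3 is accordingly estimated to give 26% in this assay, within the range 14% to 40%.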

Compound 3, a percentage reported as activity, at one dose (the size of the read-out at that dose, not a potency): 23.9%
For compound 3 the middle estimate is 2.1 percentage points above the measured one, within the range that was stated.
By their numbers in this assay, from the lowest: compounds 3, 1 and 2 (each within the scatter of the next).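

In this assay, within the data shown here, the change from 4-methylphenyl to 4-chlorophenyl is the first that can be read at a single place, with a number 1.3 percentage points lower from compound 2 to compound 3 (within the scatter) as the measured step. On this six-membered aromatic ring of carbon only, para to a large group, methyl and chloro cannot be told apart at the dose given, so this exchange of one heavy atom for one heavy atom has no effect that this read-out can resolve. Nothing at hand bears on why the two groups read alike.

The compounds shown leave open whether a group of another kind at this place, such as an amine, a carboxylic acid or a methoxy group, would separate from methyl and chloro in this read-out. They also leave open what a longer chain in place of the sulfur-bearing link shared by compound 2 and compound 3 would do, and whether methyl and chloro would still read alike at another dose.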